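The source may hold more compounds than are shown below. What is called first, only, known or untested is meant among the compounds shown, and "the series" means these compounds.

Three esters built on one coumarin-type core were measured in a functional assay on cells for positive allosteric modulation, with A2780/Taxol (Homo sapiens) as the target, read by MTT assay, with a stated time of 48 h, tested at 10 uM; on this read-out lower numbers stand for stronger inhibition and higher numbers for weaker inhibition. Compound 1 `CCOc1ccc2c(C)cc(=O)oc2c1COC(=O)c1ccc(C)cc1` gives 155 nM. Compound 2 `CCCc1ccc(C(=O)OCc2c(OCC)ccc3c(C)cc(=O)oc23)cc1` carries ethyl in place of hydrogen on a saturated chain carbon bound to an aromatic carbon, and this change produced the step of a 2.1-fold lower number from compound 1 to compound 2 (0.32 log units; beyond the scatter); in this assay compound 2 gives 74.2 nM. Compound 3 `Cc1ccc(C(=O)OCc2c(OC(C)C)ccc3c(C)cc(=O)oc23)cc1` instead carries methyl in place of hydrogen on a saturated chain carbon bound to an oxygen on an aromatic ring and a saturated chain carbon, and in this assay compound 3 gives 41.8 nM, the step being a 3.7-fold lower number from compound 1 to compound 3 (0.57 log units; beyond the scatter). The values of compound 2 and compound 3 lie within the scatter of each other, so nothing separates them.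

Compound 4 `CCCc1ccc(C(=O)OCc2c(OC(C)C)ccc3c(C)cc(=O)oc23)cc1` has not yet been measured in this assay. It differs from compound 3 by ethyl in place of hydrogen on a saturated chain carbon bound to an aromatic carbon, the same change that led from compound 1 to compound 2, at the same place; the two cores themselves differ by methyl in place of hydrogen on a saturated chain carbon bound to an oxygen on an aromatic ring and a saturated chain carbon. Because the earlier step of a 2.1-fold lower number from compound 1 to compound 2 (0.32 log units; beyond the scatter) was modest but beyond the scatter, a step of similar size, a 1.9-fold lower number from compound 3 to compound 4 (0.28 log units; within the scatter), is expected for compound 4. Compound 4 is therefore estimated at 22 nM, with a range from 9 nM to 50 nM.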

Compound 4, half-maximal inhibitory concentration: 88.6 nM
Beside the measured number, compound 4's estimate is 4.0-fold (0.61 log units) below it; measured number above the stated range.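

The change from 4-methylphenyl to 4-propylphenyl did not carry from one core to the other: on the core of compound 3 it gave a 2.1-fold higher number from compound 3 to compound 4 (0.33 log units; beyond the scatter), opposite in direction to the step seen on the core of compound 1, and the two steps differ clearly: the same change on two cores in this assay, a 2.1-fold lower number (0.32 log units; beyond the scatter) from compound 1 to compound 2 and a 2.1-fold higher number (0.33 log units; beyond the scatter) from compound 3 to compound 4, 4.4-fold (0.65 log units) apart, beyond the scatter of two such steps

The other change, methyl in place of hydrogen on a saturated chain carbon bound to an oxygen on an aromatic ring and a saturated chain carbon, gave only a 1.2-fold higher number from compound 2 to compound 4 (0.08 log units; within the scatter) once the propyl group was present, so it too depends on its setting: the same change on two cores in this assay, a 3.7-fold lower number (0.57 log units; beyond the scatter) from compound 1 to compound 3 and a 1.2-fold higher number (0.08 log units; within the scatter) from compound 2 to compound 4, 4.4-fold (0.65 log units) apart, beyond the scatter of two such steps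

Across these four compounds the two changes therefore do not add up, but this shows only that each change depends on the other in this assay, not why it does so or whether the same holds elsewhere in the series.

The compounds shown leave open how a butyl chain or a carboxylic acid in place of the propyl group would behave on either core. They also leave open whether an amine on that ring would show the same dependence on the core.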